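The source may hold more compounds than are shown below. What is called first, only, known or untested is meant among the compounds shown, and "the series" means these compounds.

Of the compounds shown here, two have been measured so far. Compound 1 `O=C(CSc1nnc(NC(=O)CCl)s1)Nc1ccc(Br)cn1` carries a five-membered ring bearing two nitrogens and a sulfur between its two amide arms, while compound 2 `O=C(CCl)Nc1ccc(SCC(=O)Nc2ccc(Br)cn2)cc1` places a benzene ring there instead; both end in the same 5-bromopyridin-2-yl amide. In a functional assay on NCI-H460 cells (Homo sapiens) for antiproliferative activity, read by MTT assay, with a stated time of 48 h (on this read-out higher numbers stand for weaker inhibition and lower numbers for stronger inhibition), compound 1 gives 7500 nM. In this assay compound 2 gives 530 nM, the lower of the two numbers, and the gap between the two lies beyond the usual scatter of repeated measurements. Compound 2 is therefore the stronger inhibitor of the pair on the numbers shown.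

Compound 3 `O=C(CCl)Nc1ccc(SCC(=O)Nc2ccccn2)cc1` keeps everything of compound 2 except for one change: hydrogen in place of bromo on an aromatic carbon. Whether a bromo at this position matters for this assay is not known from the two measured compounds, since both carry it. Losing a halogen from a ring often costs some potency, so compound 3 is expected to give a somewhat higher number than compound 2, an estimated step of a 2.8-fold higher number from compound 2 to compound 3 (0.45 log units; beyond the scatter). The estimate for compound 3 in this assay is 1500 nM, with a range from 500 nM to 5000 nM.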

Compound 3, half-maximal inhibitory concentration: 11900 nM
Compound 3: middle estimate off by 7.9-fold (0.90 log units), on the low side; the whole stated range lies below it.
By their numbers in this assay, from the lowest: compound 2; then compounds 1 and 3 (each within the scatter of the next).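

Compounds 1 and 2 both carry the bromo, so they could not show what this atom contributes; the pair of compound 2 and compound 3 can, since the bromo is the only difference between them. In this assay the change from 5-bromopyridin-2-yl to pyridin-2-yl gives a 22-fold higher number from compound 2 to compound 3 (1.35 log units; beyond the scatter) and this large step lies well beyond the usual scatter of repeated measurements. For this pair, then, a hydrogen on the aromatic carbon two atoms from the ring nitrogen is no match for the bromo, and a change of a single heavy atom at this position is enough to weaken the antiproliferative read-out greatly, though nothing available explains why this one atom counts for so much.

From the compounds shown here alone, it remains open whether a chloro, a fluoro, a methyl or a methoxy group at this same position would keep the low number of compound 2 or lose it as the hydrogen does. Going by these compounds, it is also open whether removing the bromo from compound 1 would bring a step of similar size on that different core.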